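Aryl swap at the exocyclic double bond: a bicyclic heteroaryl next

The source may report more compounds than this note shows. Statements on the series, on what has been measured and on what is new or still open speak of the compounds shown alone.

Within the data shown here, compound 2 `CCOC(=O)C1=C(Nc2ccccc2)S/C(=C\c2ccccc2O)C1=O` stands highest of the two numbers so far: in a functional assay on JAR cells (Homo sapiens) for inhibition, read by MTT assay, with a stated time of 72 h, tested at 10 uM (a lower number here means less inhibition, a higher number more inhibition at the concentration tested (going by the name of the read-out)), compound 2 gives 89.4%, with compound 1 `CCOC(=O)C1=C(Nc2ccccc2)S/C(=C\c2ccc(Br)c(O)c2)C1=O` nearest at 39.8%. Among the measured compounds shown here, the only step at this position, a number 49.6 percentage points higher from compound 1 to compound 2 (beyond the scatter), shows that exchanging the aryl group here can move the read-out a long way. Compound 3 `CCOC(=O)C1=C(Nc2ccccc2)S/C(=C\c2cc3ccncc3[nH]2)C1=O` brings (a group of 9 heavy atoms (7 carbon, 2 nitrogen; one five-membered aromatic ring with 1 hetero atom, one six-membered aromatic ring with 1 hetero atom) in place of a group of 7 heavy atoms (6 carbon, 1 oxygen; one six-membered aromatic ring of carbon only), on a double-bonded chain carbon bound to a double-bonded ring carbon). That step bears on the change only loosely, so the direction is uncertain; a drop of moderate size, a number 29.4 percentage points lower from compound 2 to compound 3 (beyond the scatter), is expected. For compound 3 the estimate is 60%, within 25% to 95%.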

Compound 3, a percentage reported as inhibition, at one concentration (the size of the read-out at that concentration, not a potency): 26.3%
Compound 3: the middle estimate sits 33.7 percentage points above what was measured; the measured number falls inside the stated range.
By their numbers in this assay, from the lowest: compound 3; then compound 1; then compound 2.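

In this assay, the group with one five-membered and one six-membered aromatic ring sits lowest of the three at this place, with a number 63.1 percentage points lower from compound 2 to compound 3 (beyond the scatter) and a number 13.5 percentage points lower from compound 1 to compound 3 (beyond the scatter). The hydrogen-bond donor and acceptor counts are the same for 2-hydroxyphenyl and the entering group, so those counts do not separate compound 2 from compound 3. Nothing at hand accounts for either drop.

As far as these compounds go, whether a 2-aminophenyl or 2-methoxyphenyl group at this place would stay near compound 2 remains open. So does whether that high number survives a carboxylic acid in place of the ethyl ester.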